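Swapping a sulfonyl for an acetyl on a ghrelin receptor blocker

The source may report more compounds than this note shows. Statements on the series, on what has been measured and on what is new or still open speak of the compounds shown alone.

Compound 1 `CCc1nc(N)nc(N)c1-c1ccc(NCc2ccc(S(C)(=O)=O)cc2)cc1` is measured in a functional assay on CHOK cells for antagonist activity at growth hormone secretagogue receptor type 1 (Homo sapiens), read by calcium flux (on this read-out higher numbers stand for weaker inhibition and lower numbers for stronger inhibition), where compound 1 gives 12 nM. Compound 3 `CCc1nc(N)nc(N)c1-c1ccc(NCc2ccc([N+](=O)[O-])cc2)cc1` gives 23 nM in this assay, and the step of a 1.9-fold higher number from compound 1 to compound 3 (0.28 log units; within the scatter) stays inside the scatter. Compound 2 `CCc1nc(N)nc(N)c1-c1ccc(NCc2cc(F)c(S(C)(=O)=O)c(F)c2)cc1` gives 45 nM, a number beyond the scatter from compound 1, so compound 1 sits at the low end of the three numbers. Compound 4 `CCc1nc(N)nc(N)c1-c1ccc(NCc2ccc(C(C)=O)cc2)cc1` carries acetyl in place of methylsulfonyl on an aromatic carbon. Among the compounds with values here, only the step from compound 1 to compound 3 bears on this change, since it too replaces the methylsulfonyl group by another group; its size was small. A step of similar size is therefore expected, estimated as a 1.7-fold higher number from compound 1 to compound 4 (0.22 log units; within the scatter). Compound 4 is expected to give about 20 nM, within 8 nM to 50 nM.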

Compound 4, half-maximal inhibitory concentration: 110 nM
Estimate against measurement, compound 4: 5.5-fold (0.74 log units) below, and the stated range ends below it.
By their numbers in this assay, from the lowest: compounds 1, 3 and 2 (each within the scatter of the next, the first and the last beyond it); then compound 4.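

Not every replacement of methylsulfonyl on this aromatic carbon is tolerated equally. Acetyl gives a 9.2-fold higher number from compound 1 to compound 4 (0.96 log units; beyond the scatter) and also a 4.8-fold higher number from compound 3 to compound 4 (0.68 log units; beyond the scatter) while nitro had stayed within the scatter of compound 1, so the earlier nitro result does not carry over to every small group at this place. Nothing measured here explains the difference between these groups. On these data alone, whether a carboxylic acid or a sulfonamide at this place would stay close to compound 1 or fall nearer compound 4 remains open.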